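One Ring Exchanged Twice: Estimating Compound 4

This account rests on a few compounds, and the source may have more. Where it says the series, first, only, none or still open, it means among the compounds named here.

Of the compounds shown here, three sharing a cinnamoyl-type chain have been tested, and a fourth awaits measurement. Compound 1 `O=C(/C=C/c1ccc(/C=N/NC(=O)c2ccncc2)cc1)c1ccc(F)cc1` carries a 4-fluorophenyl on its carbonyl carbon; in a functional assay on the whole organism (Ear) for inhibition, with Mus musculus as the target, with a stated time of 30 min, at a dose of 100 mg/kg by the intraperitoneal route (a higher number here means more inhibition at the dose given (going by the name of the read-out), a lower number less inhibition), compound 1 gives 51.1%. Compound 2 `Cc1ccc(C(=O)/C=C/c2ccc(/C=N/NC(=O)c3ccncc3)cc2)c(C)c1` carries a 2,4-dimethylphenyl instead, and compound 2 gives 58.5%. Compound 3 `Cc1ccc(C(=O)/C=C/c2ccc(/C=N/NC(=N)N)cc2)c(C)c1` keeps that 2,4-dimethylphenyl but differs in the core: a group of 3 heavy atoms (1 carbon, 2 nitrogen; no ring) in place of a group of 8 heavy atoms (6 carbon, 1 nitrogen, 1 oxygen; one six-membered aromatic ring with 1 hetero atom), on an amine nitrogen. In this assay compound 3 gives 64.2%.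

Two steps are known. The change 4-fluorophenyl in place of 2,4-dimethylphenyl on a carbonyl carbon made a step of a number 7.4 percentage points lower from compound 2 to compound 1 (within the scatter). The core change a group of 3 heavy atoms (1 carbon, 2 nitrogen; no ring) in place of a group of 8 heavy atoms (6 carbon, 1 nitrogen, 1 oxygen; one six-membered aromatic ring with 1 hetero atom), on an amine nitrogen made a step of a number 5.7 percentage points higher from compound 2 to compound 3 (within the scatter). Between compound 3 and compound 1 the gap is beyond the scatter, while compound 3 and compound 2 sit within it.

Compound 4 `N=C(N)N/N=C/c1ccc(/C=C/C(=O)c2ccc(F)cc2)cc1` differs from compound 3 by 4-fluorophenyl in place of 2,4-dimethylphenyl on a carbonyl carbon. The place of this change reads word for word as in the change from compound 2 to compound 1, so it is the same change, applied once on each core; among the compounds shown it occurs twice in all.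

The step expected from compound 3 to compound 4 is estimated as a number 7.2 percentage points lower from compound 3 to compound 4 (within the scatter), resting on the earlier measured step of a number 7.4 percentage points lower from compound 2 to compound 1 (within the scatter) made by the same change. Because of 64.2% for compound 3, compound 4 is expected to give 57% in this assay, with a range from 42% to 70%.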

Compound 4, a percentage reported as inhibition, in the whole organism at one dose (the size of the read-out at that dose, not a potency): 90.7%
Estimate against measurement, compound 4: 33.7 percentage points below; measured number outside the range, above it.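

In this assay the exchange of 2,4-dimethylphenyl for 4-fluorophenyl on a carbonyl carbon gave a number 26.5 percentage points higher from compound 3 to compound 4 (beyond the scatter), and this step does not match the one seen on the other core: the same change on two cores in this assay, a number 7.4 percentage points lower (within the scatter) from compound 2 to compound 1 and a number 26.5 percentage points higher (beyond the scatter) from compound 3 to compound 4, 33.9 percentage points apart, beyond the scatter of two such steps

The core change, which gave a number 39.6 percentage points higher from compound 1 to compound 4 (beyond the scatter), likewise depends on which group sits on the carbonyl carbon: the same change on two cores in this assay, a number 5.7 percentage points higher (within the scatter) from compound 2 to compound 3 and a number 39.6 percentage points higher (beyond the scatter) from compound 1 to compound 4, 33.9 percentage points apart, beyond the scatter of two such steps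

Both comparisons rest on the same four compounds and describe a single departure from simple addition, so they show that in this set a step measured on one core could not be carried over to the other, but they do not show why, nor how any other pair of groups would behave.

The compounds shown leave open whether the high number of compound 4 goes with the fluorine or with the absence of the methyl groups, a question that an unsubstituted phenyl or a 4-methylphenyl on the carbonyl carbon, placed on each core, could help to settle. They also leave open whether the same dependence would hold for a 4-chlorophenyl, or for a different group on the amine nitrogen, such as a urea.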